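Cutting the side chain of compound 2 to methyl

The source may report more compounds than this note shows. Statements on the series, on what has been measured and on what is new or still open speak of the compounds shown alone.

- compound 1 `COc1ncc(-c2ccc3nc(NC(=O)NCCN4CCCCC4)nn3c2)cc1NS(=O)(=O)c1ccc(F)cc1` gives 150 nM
- compound 2 `COc1ncc(-c2ccc3nc(NC(=O)NCC(=O)N4CCCC4)nn3c2)cc1NS(=O)(=O)c1ccc(F)cc1` gives 140 nM
- compound 3 `CCN(CC)CCNC(=O)Nc1nc2ccc(-c3cnc(OC)c(NS(=O)(=O)c4ccc(Cl)cc4)c3)cn2n1` gives 120 nM

In a functional assay on HCT-116 cells (Homo sapiens) for cytotoxicity, read by MTT assay, with a stated time of 72 h (a lower number here means a stronger inhibitor, a higher number a weaker inhibitor), these three values lie close together, and compound 2 cannot be told apart from either of the other two. The next compound to be measured is compound 4 `CNC(=O)Nc1nc2ccc(-c3cnc(OC)c(NS(=O)(=O)c4ccc(F)cc4)c3)cn2n1`. It differs from compound 2 as follows: hydrogen in place of (pyrrolidin-1-yl)carbonyl on a saturated chain carbon bound to an amide-type nitrogen. Put simply, the ((pyrrolidin-1-yl)carbonyl)methyl group becomes a plain methyl.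

Among the measured compounds shown here, only one measured step bears directly on this place: a 1.1-fold lower number from compound 1 to compound 2 (0.03 log units; within the scatter). Exchanging one large group for another there left the number practically unchanged. That step replaced the group, however, and did not remove it. For the measured compounds named here, no measured compound shows what happens when the group is lost altogether, so the evidence is thin. Going by the values given here, compound 3 differs from compound 2 in more than one place, and its value adds only that a third compound falls in the same narrow band.

A small move toward a weaker inhibitor seems the most likely outcome, with a wide margin either way. The expected step is a 1.4-fold higher number from compound 2 to compound 4 (0.15 log units; within the scatter). Compound 4 is estimated at 200 nM, within an expected range of 70 nM to 600 nM.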

Compound 4, half-maximal inhibitory concentration: 180 nM
Compound 4: middle estimate off by 1.1-fold (0.05 log units), on the high side; the range from low to high includes it.
By their numbers in this assay, from the lowest: compounds 3, 2, 1 and 4 (each within the scatter of the next).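

Among the compounds shown here, until now the only step at this place swapped one large group for another, whereas here the group goes altogether and only hydrogen remains on the saturated chain carbon bound to an amide-type nitrogen. In this assay, this loss of the (pyrrolidin-1-yl)carbonyl group gives (a 1.3-fold higher number from compound 2 to compound 4 (0.11 log units; within the scatter)), and the matching loss of the (piperidin-1-yl)methyl group gives (a 1.2-fold higher number from compound 1 to compound 4 (0.08 log units; within the scatter)), so compound 1, compound 2 and compound 4 cannot be told apart, and among these three a large group at this place is not needed to keep the number in this range. Nothing measured here explains why the number holds when so much of the side chain is gone.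

On these data alone, it remains open whether any group at this place can shift the number beyond the scatter, for example a carboxylic acid or a primary amine at the end of the chain. A longer plain carbon chain such as butyl, or a hydrogen in place of the methyl itself, would show whether this tolerance extends further in either direction.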